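A Chloro Substituent on the Fused Ring, Read for Cytotoxicity

This account rests on a few compounds, and the source may have more. Where it says the series, first, only, none or still open, it means among the compounds named here.

The measured compounds and their values:
compound 1 `CN(C)CCN1CCN(CC(=O)Nc2ccc(-c3nc4cc(Cl)ccc4o3)cc2)CC1`: 28700 nM
compound 2 `CN(C)CCN1CCN(CC(=O)Nc2ccc(-c3nc4ccccc4o3)cc2)CC1`: 35800 nM
compound 3 `Cc1cc(-c2nc3ccccc3o2)ccc1NC(=O)CCl`: 12200 nM

In an ADME assay on NIH3T3 cells (Mus musculus) for cytotoxicity, read by MTT assay, with a stated time of 24 h (a lower number here means a stronger inhibitor, a higher number a weaker inhibitor), compound 3 gives the lowest of the three numbers, and its gaps to compound 1 and compound 2 are both beyond the usual scatter. Compound 2 and compound 1 differ by one change, (chloro in place of hydrogen on an aromatic carbon), and that change made a 1.2-fold lower number from compound 2 to compound 1 (0.10 log units; within the scatter). Compound 3 and compound 2 differ in more than one place; the difference between their cores is not broken down here.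

Compound 4 `Cc1cc(-c2nc3cc(Cl)ccc3o2)ccc1NC(=O)CCl` has not yet been measured. It differs from compound 3 by chloro in place of hydrogen on an aromatic carbon, the same change that separates compound 2 from compound 1, made at the same place on the fused ring. Among the compounds with values here, the only guide for compound 4 is that earlier step, which stayed within the scatter. On that basis the expected step is a 1.2-fold lower number from compound 3 to compound 4 (0.07 log units; within the scatter), resting on a 1.2-fold lower number from compound 2 to compound 1 (0.10 log units; within the scatter). Compound 4 is therefore estimated at 10500 nM in this assay, with a likely range from 5000 nM to 25000 nM.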

Compound 4, half-maximal inhibitory concentration: 8640 nM
Beside the measured number, compound 4's estimate is 1.2-fold (0.08 log units) above it, within the range that was stated.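

In this assay, chloro in place of hydrogen on an aromatic carbon of the fused ring gave a 1.4-fold lower number from compound 3 to compound 4 (0.15 log units; within the scatter). Set beside the same change on the other core, the two steps agree: the same change on two cores in this assay, a 1.2-fold lower number (0.10 log units; within the scatter) from compound 2 to compound 1 and a 1.4-fold lower number (0.15 log units; within the scatter) from compound 3 to compound 4, 1.1-fold (0.05 log units) apart, within the scatter of two such steps. This shows that the change carried over from one core to the other without a detectable difference between the steps, but since each step lies within the scatter, it does not show that chloro shifts the number on either core, and two cores cannot establish a rule for the series.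

The compounds shown hold only hydrogen or chloro at this place, which leaves open how a bromo, a methoxy or an amine there would read. Also open is whether the step would stay the same with a longer chain or a carboxylic acid in place of the side chains shown.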